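Benzyl for butyl on the carbamate in a triazole series

The compounds below may be only part of what the source reports. "The series", "measured", "known", "first", "only" and "open" are said of these compounds alone.

Measured compounds:
compound 1, `CCCCNC(=O)OCC(O)Cn1cc(CN(C)CCC(C)C)nn1`: 24%
compound 2, `CCCCNC(=O)OCC(O)Cn1cc(CN2CCCC(C(=O)OCC)C2)nn1`: 24%
compound 3, `CC(C)CCN(C)Cc1cn(CC(O)COC(=O)NCc2ccccc2)nn1`: 26%

The three measured compounds were tested in an assay on nucleic acid for inhibition of Nucleic Acid, read by fluorescence, tested at 100 uM; on this read-out lower numbers stand for less inhibition and higher numbers for more inhibition at the one concentration tested (going by the name of the read-out). Compound 1 gives 24%, and compound 2 gives 24%, so the two stand level at the digits reported and together form the lowest pair of the three numbers. Compound 3 gives 26%. The difference between the cores of compound 1 and compound 2 is not broken down here.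

Compound 1 and compound 3 differ in one place only: phenyl in place of propyl on a saturated chain carbon bound to an amide-type nitrogen. That change made a step of a number 2 percentage points higher from compound 1 to compound 3 (within the scatter), a step that lies within the usual scatter of this kind of measurement, so nothing can be read into its direction.

Compound 4, `CCOC(=O)C1CCCN(Cc2cn(CC(O)COC(=O)NCc3ccccc3)nn2)C1`, has not yet been measured in this assay. It stands to compound 2 exactly as compound 3 stands to compound 1, by the same change, (phenyl in place of propyl on a saturated chain carbon bound to an amide-type nitrogen), at the same place. Going by the values given here, because the only precedent for this change is the step of a number 2 percentage points higher from compound 1 to compound 3 (within the scatter), and because compound 2 starts from 24%, level with compound 1, compound 4 is expected to land close to where compound 2 sits, with a step of about a number 2 percentage points higher from compound 2 to compound 4 (within the scatter). The estimate for compound 4 in this assay is therefore 26%, expected to fall between 16% and 36%.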

Compound 4, a percentage reported as inhibition, at one concentration (the size of the read-out at that concentration, not a potency): 47%
Beside the measured number, compound 4's estimate is 21 percentage points below it; the whole stated range lies below it.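

In this assay, phenyl in place of propyl on a saturated chain carbon bound to an amide-type nitrogen, which is the same difference as butyl to benzyl, made a step of a number 23 percentage points higher from compound 2 to compound 4 (beyond the scatter). Set beside the earlier case, the change did not carry over at the same size from one core to the other: the same change on two cores in this assay, a number 2 percentage points higher (within the scatter) from compound 1 to compound 3 and a number 23 percentage points higher (beyond the scatter) from compound 2 to compound 4, 21 percentage points apart, beyond the scatter of two such steps

This shows that in this series the size of the step cannot be taken from one core and applied to another, and that the benzyl carbamate gains over the butyl carbamate on the core of compound 2 but shows no readable gain on the core of compound 1. Going by these compounds alone, it does not show which feature of the two cores sets the steps apart, and with only two pairs, each read at a single concentration, it gives no rule for other cores and no measure of potency.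

The compounds shown leave open whether the larger step would persist on the core of compound 2 with a carboxylic acid in place of the ethyl ester. They also leave open whether a longer chain such as phenethyl in place of benzyl on the carbamate would give a step of similar size on either core.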